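Series notes: three limits and one untested amide

The source may report more compounds than this note shows. Statements on the series, on what has been measured and on what is new or still open speak of the compounds shown alone.

Compound 1 `CON(C)C(=O)[C@H]1CC2=C(CCCC2(C)C)C[C@@H]1c1ccccc1` in an assay on isolated protein for inhibition of Apoptosis regulator Bcl-2 (Homo sapiens), read by fluorescence polarization, with stated times of 5 min and 10 min (on this read-out lower numbers stand for stronger inhibition and higher numbers for weaker inhibition), gives > 23000 nM, a limit of the assay.
Compound 2 `COC(=O)c1ccc(NC(=O)[C@H]2CC=C(CCC=C(C)C)C[C@@H]2c2ccccc2)cc1` in this assay gives > 23000 nM, likewise a limit.
Compound 3 `CC1(C)CCCC2=C1C[C@H](C(=O)O)[C@@H](c1ccccc1)C2` in this assay gives > 23000 nM, also a limit.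

Compound 2 therefore stands only at the assay limit, and since the other two values shown are limits as well, its place relative to them cannot be told. Going by the values given here, the single step between measured compounds, a step that the two limits leave unreadable from compound 1 to compound 3, runs between two limits and its size is not readable. All three values sit at the limit of > 23000 nM in this assay, at which 3 of the 3 values shown sit. Compound 4 `CC(C)=CCCC1=CC[C@H](C(=O)NCCC(=O)O)[C@@H](c2ccccc2)C1` carries 2-carboxyethyl in place of 4-(methoxycarbonyl)phenyl on an amide-type nitrogen. Among the compounds with values here, no measured step bears on this change, and the series offers no number to anchor it, so the expected step that the limit leaves unreadable from compound 2 to compound 4 is weakly founded. Compound 4 is expected at 30000 nM, within 8000 nM to 100000 nM, most probably again a limit in this assay.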

Compound 4, inhibition constant: > 23000 nM
Compound 4: a limit, no number (the forecaster's own chance of this, stated with the estimate: 80%); the middle value does not contradict the limit.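

Going by these compounds alone, compound 2 and compound 4 both give limits rather than numbers, so no step between them can be read. The compounds shown leave open whether any change in this series alters inhibition at all: the limit of > 23000 nM in this assay, at which 4 of the 4 values shown sit.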